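Replacing a Nitro Group on a Pyridine Ether

A few compounds are considered here, and "the series" means these few. Any claim that something is new, unique, unknown or untested is made for them only; others in the source may bear on it.

Measured so far:
- compound 1 `CCc1cncc(OC[C@@H]2CCN2)c1`, 0.1 nM
- compound 2 `O=[N+]([O-])c1cncc(OC[C@@H]2CCN2)c1`, 0.33 nM

Both compounds were tested in an assay on brain for binding affinity to Neuronal acetylcholine receptor; alpha4/beta2 (Rattus norvegicus), read by radioligand binding; on this read-out higher numbers stand for weaker inhibition and lower numbers for stronger inhibition. Among the measured compounds shown here, compound 2 has the higher of the two numbers; the only neighbour is compound 1, and the step of a 3.3-fold higher number from compound 1 to compound 2 (0.52 log units; beyond the scatter) shows how far apart they sit. Compound 3 `CC(=O)NCc1cncc(OC[C@@H]2CCN2)c1` has not been measured yet. It differs from compound 2 by acetamidomethyl in place of nitro on an aromatic carbon. For the measured compounds named here, the one step seen so far, a 3.3-fold higher number from compound 1 to compound 2 (0.52 log units; beyond the scatter), was modest and came from swapping one small group for another at the same place. Going by the values given here, the change to compound 3 puts in a larger group with a hydrogen-bond donor where none was before, and no measured pair shows what such a group does here. The expectation is therefore a somewhat larger rise in the number, by about a 9.1-fold higher number from compound 2 to compound 3 (0.96 log units; beyond the scatter). Compound 3 is thus estimated at 3 nM, with a plausible range from 0.5 nM to 15 nM.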

Compound 3, inhibition constant: 0.54 nM
Compound 3: the middle estimate sits 5.6-fold (0.74 log units) above what was measured; low and high end bracket the measured number.
By their numbers in this assay, from the lowest: compound 1; then compounds 2 and 3 (each within the scatter of the next).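

Swapping nitro for acetamidomethyl on this aromatic carbon gives, in this assay, (a 1.6-fold higher number from compound 2 to compound 3 (0.21 log units; within the scatter)), so this position holds a group with more heavy atoms and a hydrogen-bond donor without a shift beyond the usual scatter. The ethyl group of compound 1 still gives a clearly lower number, with the acetamido-for-methyl change at the end of that chain giving (a 5.4-fold higher number from compound 1 to compound 3 (0.73 log units; beyond the scatter)), so not every change here is equally well accepted. No supporting data explain either step.

The compounds shown leave open whether the amide hydrogen matters, which a version with a methyl group on the amide nitrogen could test. They also leave open how a plain aminomethyl group, a carboxylic acid or a longer chain would behave at this position.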